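The source may report more compounds than this note shows. Statements on the series, on what has been measured and on what is new or still open speak of the compounds shown alone.

Compound 1 `CCCSc1nnc(Cc2ccc(Cl)cc2Oc2ccccc2Cl)[nH]1` carries a propylsulfanyl group on its triazole core and a 2-chlorophenoxy group on the benzyl ring. In a functional assay on the whole organism (strain NMRI) with Mus musculus as the target, with a stated time of 60 min, at a dose of 10 mg/kg by the intraperitoneal route (a lower number here means a weaker effect, a higher number a stronger effect of the compound at the dose given), compound 1 gives 125%. Compound 2 `CCCSc1nnc(Cc2ccc(Cl)cc2Oc2ccccc2F)[nH]1` differs by fluoro in place of chloro on an aromatic carbon, and in this assay compound 2 gives 127%, so that a number 2 percentage points higher from compound 1 to compound 2 (within the scatter). Compound 3 `CCOc1nnc(Cc2ccc(Cl)cc2Oc2ccccc2Cl)[nH]1` keeps the 2-chlorophenoxy group but its core differs from that of compound 1 by ethoxy in place of propylsulfanyl on an aromatic carbon; in this assay compound 3 gives 122%, and a number 3 percentage points lower from compound 1 to compound 3 (within the scatter). Compound 4 `CCOc1nnc(Cc2ccc(Cl)cc2Oc2ccccc2F)[nH]1` has not yet been measured; it differs from compound 3 by fluoro in place of chloro on an aromatic carbon, the same change that separates compound 1 from compound 2. Because the earlier step was a number 2 percentage points higher from compound 1 to compound 2 (within the scatter), the expected step is a number 2 percentage points higher from compound 3 to compound 4 (within the scatter). Compound 4 is therefore estimated at 124% in this assay, between 110% and 138%.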

Compound 4, a percentage reported as activity, at one dose (the size of the read-out at that dose, not a potency): 116%
Compound 4: middle estimate off by 8 percentage points, on the high side, and the stated range covers the measured number.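

In this assay, fluoro in place of chloro now gives a number 6 percentage points lower from compound 3 to compound 4 (within the scatter), and beside the earlier step this change shows no difference that can be told apart between the two cores: the same change on two cores in this assay, a number 2 percentage points higher (within the scatter) from compound 1 to compound 2 and a number 6 percentage points lower (within the scatter) from compound 3 to compound 4, 8 percentage points apart, within the scatter of two such steps. Ethoxy in place of propylsulfanyl gives a number 11 percentage points lower from compound 2 to compound 4 (beyond the scatter), and this step does not separate from its counterpart either: the same change on two cores in this assay, a number 3 percentage points lower (within the scatter) from compound 1 to compound 3 and a number 11 percentage points lower (beyond the scatter) from compound 2 to compound 4, 8 percentage points apart, within the scatter of two such steps. Each change thus carries between these two cores within the scatter, but this does not show that either step has a constant size or would hold on any other core in the series. The compounds shown leave open what an amine or a longer chain would do in place of the ethoxy or propylsulfanyl group. They also leave open how a bromo group would compare with chloro and fluoro on the phenoxy ring.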